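A few compounds are considered here, and "the series" means these few. Any claim that something is new, unique, unknown or untested is made for them only; others in the source may bear on it.

Compound 1 `O=S(=O)(Nc1ccc(-c2nc3ccccc3o2)cc1)c1cccs1` and compound 2 `O=S(=O)(Nc1ccc(-c2nc3ccccc3o2)cc1)c1ccc(O)cc1` share one core and differ only in the group on the sulfonyl sulfur. In an assay on isolated protein for inhibition of malate dehydrogenase, mitochondrial (Sus scrofa), with stated times of 45 min and 30 min (on this read-out lower numbers stand for stronger inhibition and higher numbers for weaker inhibition), compound 1 gives > 63000 nM, which is a limit of the assay and not a number. In this assay compound 2 likewise gives > 63000 nM, again a limit of the assay. Both values sit at the limit of > 63000 nM in this assay, at which 2 of the 2 values shown sit, and the step that the two limits leave unreadable from compound 1 to compound 2 is therefore not readable in size or direction. Compound 2 thus stands at the limit, with no number placing it against any other member of the series. Compound 3 `COc1ccc(S(=O)(=O)Nc2ccc(-c3nc4ccccc4o3)cc2)cc1` differs from compound 2 by methyl in place of hydrogen on an oxygen on an aromatic ring. Among the measured compounds shown here, no measured step bears on this change: the single step available is unreadable, and no other pair touches the oxygen. The step that the limit leaves unreadable from compound 2 to compound 3 is accordingly expected to be none beyond the scatter. Compound 3 is estimated at 100000 nM in this assay, within 30000 nM to 400000 nM, most probably reported again only as a limit.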

Compound 3, half-maximal inhibitory concentration: > 63000 nM
Compound 3 gave a limit, no number (the forecaster's own chance of this, stated with the estimate: 85%); the middle value is on the limit's open side.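

The steps among compound 1, compound 2 and compound 3 cannot be read in size or direction in this assay, as all three values are limits of the assay and not numbers: the limit of > 63000 nM in this assay, at which 3 of the 3 values shown sit.
The compounds shown leave open whether any group on the sulfonyl sulfur gives measurable inhibition, and how thiophen-2-yl, 4-hydroxyphenyl and 4-methoxyphenyl rank.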